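This account rests on a few compounds, and the source may have more. Where it says the series, first, only, none or still open, it means among the compounds named here.

In a functional assay on HUVEC cells (Homo sapiens) for antiproliferative activity, read by MTT assay, with a stated time of 24 h (a lower number here means a stronger inhibitor, a higher number a weaker inhibitor), the three measured compounds stand as follows.
Compound 1, `COc1cc(OC)c(-c2coc3cc(OCc4ccccc4)ccc3c2=O)cc1OC`, gives 9750 nM.
Compound 2, `COc1ccc2c(=O)c(-c3cc(OC)c(OC)cc3OC)coc2c1`, reaches only the limit of the assay, > 10000 nM, so no number is known for it.
Compound 3, `COc1cc(OC)c(-c2coc3cc(OCc4ccc(F)cc4)ccc3c2=O)cc1OC`, likewise reaches only the limit, > 10000 nM.

Compound 2 thus stands at the limit (the limit of > 10000 nM in this assay, at which 2 of the 3 values shown sit), together with compound 3, and only compound 1 returns a number, which sits just inside that limit. Compound 4, `COc1cc(OC)c(-c2coc3cc(OCc4ccccc4Cl)ccc3c2=O)cc1OC`, differs from compound 2 by 2-chlorophenyl in place of hydrogen on a saturated chain carbon bound to an oxygen on an aromatic ring. The measured steps that bear on this change are an at least 1.0-fold higher number from compound 1 to compound 2 (0.01 log units; that floor lies within the scatter) and a step that the two limits leave unreadable from compound 2 to compound 3: putting phenyl or 4-fluorophenyl on the saturated chain carbon bound to an oxygen on the aromatic ring gave either a number close to the limit or the limit itself, so neither step shows a readable direction. The 2-chlorophenyl entering in compound 4 sits at the same place, and no step beyond the scatter is expected in this assay. Compound 4 is therefore expected to sit at or near the limit, with an estimate of 10000 nM and a range from 5000 nM to 30000 nM. This estimate means an expected step of a number no higher from compound 2 to compound 4 (the limit leaves the size open).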

Compound 4, half-maximal inhibitory concentration: > 10000 nM
Compound 4: no number, only a limit; the forecaster's own chance of this, stated with the estimate: 60%; the middle value lies on the limit itself.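

In this assay, compound 4 gives only a limit, > 10000 nM, and not a number. Putting a chlorine on the phenyl group gives an at least 1.0-fold higher number from compound 1 to compound 4 (0.01 log units; that floor lies within the scatter), so this second halogen-bearing phenyl group, like the 4-fluorophenyl of compound 3, shows no readable gain or loss against the plain phenyl of compound 1. The steps among compounds 2, 3 and 4 cannot be read, and the set now gathers at a single ceiling: the limit of > 10000 nM in this assay, at which 3 of the 4 values shown sit.

The compounds shown leave open whether any group at this place can bring the number clearly below that limit. An amine or a carboxylic acid on the added phenyl ring, or a longer chain between that ring and the oxygen, could test this.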